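Methoxy in place of chloro: expected cytotoxicity of compound 3

The compounds below may be only part of what the source reports. "The series", "measured", "known", "first", "only" and "open" are said of these compounds alone.

Compound 2 `Clc1cccc(-c2cnc(Nc3ccc4[nH]ncc4c3)o2)c1` was tested in an ADME assay on MT4 cells (Homo sapiens) for cytotoxicity, read by WST assay; on this read-out lower numbers stand for higher toxicity in this test and higher numbers for lower toxicity in this test. In this test compound 2 reaches only a limit of > 100 uM, not a number. Compound 1 `c1ccc(-c2cnc(Nc3ccc4[nH]ncc4c3)o2)cc1` likewise ends at a limit of > 90 uM in this assay. Going by the values given here, the only measured step, a step that the two limits leave unreadable from compound 1 to compound 2, bears on the change but offers no size. Compound 3 `COc1cccc(-c2cnc(Nc3ccc4[nH]ncc4c3)o2)c1` differs from compound 2 by methoxy in place of chloro on an aromatic carbon. Among the compounds with values here, with limits as the sole guide, the estimated step of a number no higher from compound 2 to compound 3 (the limit leaves the size open) is expected to stay within the scatter. Compound 3 is therefore expected to give 100 uM in this assay, between 45 uM and 200 uM.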

Compound 3, half-maximal toxic concentration: > 90 uM
Compound 3 was reported as a limit (the forecaster's own chance of this, stated with the estimate: 80%); the middle value is on the limit's open side.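

In this assay, going by these compounds alone, compound 1, compound 2 and compound 3 all end at limits rather than numbers, so no step between them can be read. The compounds shown leave open whether hydrogen, chloro or methoxy at this place gives any difference in toxic concentration.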